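Cytotoxicity of Aryloxy Quinazolines in MT4 Cells

The source may report more compounds than this note shows. Statements on the series, on what has been measured and on what is new or still open speak of the compounds shown alone.

Measured compounds:
compound 1, `COc1ccccc1Oc1nc(Nc2ccc(C#N)cc2)nc2ccccc12`, 150000 nM
compound 2, `N#Cc1ccc(Nc2nc(Oc3ccc(Cl)cc3Cl)c3ccccc3n2)cc1`, 32000 nM
compound 3, `COc1ccc(Oc2nc(Nc3ccc(C#N)cc3)nc3ccccc23)cc1`, 340000 nM

In an ADME assay on MT4 cells (Homo sapiens) for cytotoxicity, read by MTT assay, with a stated time of 4 days (on this read-out lower numbers stand for higher toxicity in this test and higher numbers for lower toxicity in this test), compound 3 gives the highest number of the three, with a 2.3-fold higher number from compound 1 to compound 3 (0.36 log units; beyond the scatter) and an 11-fold higher number from compound 2 to compound 3 (1.03 log units; beyond the scatter) setting it apart from both neighbours. Compound 4, `COc1cc(C#N)ccc1Oc1nc(Nc2ccc(C#N)cc2)nc2ccccc12`, differs from compound 3 by 4-cyano-2-methoxyphenyl in place of 4-methoxyphenyl on an oxygen on an aromatic ring. Going by the values given here, no measured step introduces a nitrile on this phenyl, so only the methoxy position bears on the change: the step of a 2.3-fold higher number from compound 1 to compound 3 (0.36 log units; beyond the scatter) shows that moving the methoxy group between positions shifts the number modestly, and compound 4 carries the 2-methoxy pattern of compound 1. The added nitrile is uncharted. Compound 4 is therefore expected to show a 2.3-fold lower number from compound 3 to compound 4 (0.36 log units; beyond the scatter), a modest decrease, with an estimate of 150000 nM and a range from 50000 nM to 400000 nM.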

Compound 4, half-maximal cytotoxic concentration: >= 140000 nM
Compound 4 was reported as a limit; the forecaster's own chance of this, stated with the estimate: 20%; the middle value lies beyond the limit too.
By their numbers in this assay, from the lowest: compound 2; then compound 1; then compound 3.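

In this assay, compound 4 is reported only as a limit: the limit of >= 140000 nM in this assay, at which 1 of the 4 values shown sits. With an at least 4.3-fold higher number from compound 2 to compound 4 (0.64 log units; beyond the scatter), 4-cyano-2-methoxyphenyl on this oxygen joins the two methoxyphenyl groups of compound 1 and compound 3 in giving a higher number than the 2,4-dichlorophenyl group of compound 2. The steps from compound 1 and compound 3 to compound 4 cannot be read, so the added nitrile has no measurable size here. From the compounds shown here alone, it remains open how far compound 4 truly lies from those two compounds, and how an amine or a carboxylic acid in place of the nitrile would read.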